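Thiosemicarbazones of pyridine: removing the ring methyl

The compounds below may be only part of what the source reports. "The series", "measured", "known", "first", "only" and "open" are said of these compounds alone.

Measured so far in a functional assay on HeLa cells (Homo sapiens) for cytotoxicity, read by MTT assay, with a stated time of 72 h, tested at 3 uM; on this read-out higher numbers stand for more inhibition of growth at the one concentration tested and lower numbers for less inhibition of growth:
compound 1 `Cc1ccnc(/C(N)=N/NC(=S)N2CCSCC2)c1`, 40.4%
compound 2 `Cc1ccnc(/C(N)=N/NC(=S)N2CCCC2)c1`, 52.1%

Compound 1 stands lowest of the two numbers; the nearest is compound 2, reached by a number 11.7 percentage points higher from compound 1 to compound 2 (beyond the scatter), a change on the thiocarbonyl carbon. Compound 3 `N/C(=N\NC(=S)N1CCSCC1)c1ccccn1` differs from compound 1 at another place: hydrogen in place of methyl on an aromatic carbon. Going by the values given here, no measured step touches this position, so the one known step gives no guide to its size or direction. Without such a step, no change beyond the scatter is expected; the estimated step is a number 0.4 percentage points lower from compound 1 to compound 3 (within the scatter). Compound 3 is therefore expected to give 40%, within 25% to 55%.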

Compound 3, percent growth inhibition at one concentration: 39.7%
Compound 3: middle estimate off by 0.3 percentage points, on the high side; measured number inside the range.
By their numbers in this assay, from the lowest: compounds 3 and 1 (each within the scatter of the next); then compound 2.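

In this assay hydrogen in place of methyl on an aromatic carbon, opposite the ring nitrogen, gives a number 0.7 percentage points lower from compound 1 to compound 3 (within the scatter) with the thiomorpholin-4-yl group held constant. For this pair, the methyl is therefore not required to retain the growth inhibition seen at the one concentration tested. No available data bear on the reason for this result. Still open, as far as these compounds go, is whether the same swap would read alike with the pyrrolidin-1-yl group of compound 2. Also open, from the compounds shown here alone, is how an amine or a carboxylic acid on this aromatic carbon would read.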